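A few compounds are considered here, and "the series" means these few. Any claim that something is new, unique, unknown or untested is made for them only; others in the source may bear on it.

Measured in a functional assay on UACC-62 cells (Homo sapiens) for cytotoxicity, read by sulforhodamine B assay; a higher number here means a weaker inhibitor of growth, a lower number a stronger inhibitor of growth:
- compound 1 `CC1=CC[C@@H]([C@@](C)(O)CCCC(C)(C)NC(=S)N/N=C\c2ccc(C)cc2)CC1`: 11600 nM
- compound 2 `CC1=CC[C@@H]([C@@](C)(O)CCCC(C)(C)NC(=S)N/N=C\c2ccccc2[N+](=O)[O-])CC1`: 6050 nM
- compound 3 `CC1=CC[C@@H]([C@@](C)(O)CCCC(C)(C)NC(=S)N/N=C\c2cccc([N+](=O)[O-])c2)CC1`: 7840 nM

Compound 3, at 7840 nM, lies within the scatter of both other compounds, so the three numbers cannot be ranked. The next compound is compound 4 `CC1=CC[C@@H]([C@@](C)(O)CCCC(C)(C)NC(=S)N/N=C\c2ccc(Cl)cc2)CC1`, with this change: 4-chlorophenyl in place of 3-nitrophenyl on a carbon with a double bond to nitrogen. In words, this is 4-chlorophenyl in place of 3-nitrophenyl on a carbon with a double bond to nitrogen.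

Within the data shown here, three measured steps bear on this change, all exchanges of the group at the same place: a 1.9-fold lower number from compound 1 to compound 2 (0.28 log units; within the scatter), a 1.5-fold lower number from compound 1 to compound 3 (0.17 log units; within the scatter) and a 1.3-fold higher number from compound 2 to compound 3 (0.11 log units; within the scatter). Among the measured compounds shown here, none of them goes beyond the scatter, and no compound among the three goes against that. For the measured compounds named here, the 4-chlorophenyl group itself has no measurement yet, so this remains an extrapolation. In this assay, no shift beyond the scatter is expected, and the expected step is a 1.0-fold higher number from compound 3 to compound 4 (0.01 log units; within the scatter). The estimate for compound 4 is 8000 nM, with an expected range of 4000 nM to 16000 nM.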

Compound 4, concentration for 50% growth inhibition: 7350 nM
The estimate for compound 4 lay 1.1-fold (0.04 log units) above the measured number; the range from low to high includes it.
By their numbers in this assay, from the lowest: compounds 2, 4, 3 and 1 (each within the scatter of the next).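

In this assay, 4-chlorophenyl on a carbon with a double bond to nitrogen extends the set to a group without nitro, and its number stays within the scatter of both nitro compounds (a 1.1-fold lower number from compound 3 to compound 4 (0.03 log units; within the scatter); a 1.2-fold higher number from compound 2 to compound 4 (0.08 log units; within the scatter)). Chloro in place of methyl on an aromatic carbon is the first step here that exchanges only the substituent on the phenyl group, and it too stays within the scatter (a 1.6-fold lower number from compound 1 to compound 4 (0.20 log units; within the scatter)). No supporting data explain why these numbers remain so close.

The compounds shown hold only methyl, nitro or chloro on the phenyl group, so an amine or a carboxylic acid there, or a longer chain in place of the phenyl group, remains open. Also open, as far as these compounds go, is whether any group at this place moves the number beyond the scatter, and how changes elsewhere in the shared core would read.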